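The source may hold more compounds than are shown below. What is called first, only, known or untested is meant among the compounds shown, and "the series" means these compounds.

Measured compounds and their numbers:

Compound 1 `O=C(O)c1cc(-c2cccc(COc3ccc4c(c3)CN(CC3CC3)C4=O)c2)ccc1Cl` gives 80 nM in an assay on HEK293 cells for positive allosteric modulation of metabotropic glutamate receptor 2 (Rattus norvegicus), read by thallium flux; a lower number here means that less compound is needed, a higher number that more compound is needed for the effect.
Compound 2 `CC(C)N1Cc2cc(OCc3cccc(-c4ccc(Cl)c(C(=O)O)c4)c3)ccc2C1=O` gives 70 nM in this assay.
Compound 3 `Cc1c(OCc2cccc(-c3ccc(Cl)c(C(=O)O)c3)c2)cc2c(c1C)C(=O)C(C1CCCC1)C2` gives 180 nM in this assay.

Compound 2 has the lowest number of the three, but only its gap to compound 3 exceeds the scatter; compound 3 also carries a different core, so its value says little about the amide nitrogen substituent. Between compound 1 and compound 2 the only change is the group on the amide-type nitrogen in the ring, and that step, a 1.1-fold lower number from compound 1 to compound 2 (0.06 log units; within the scatter), stays within the scatter.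

Compound 4 `O=C(O)c1cc(-c2cccc(COc3ccc4c(c3)CN(C3CC3)C4=O)c2)ccc1Cl` continues along the same nitrogen. The change is cyclopropyl in place of isopropyl on an amide-type nitrogen in a ring. Going by the values given here, the one measured step that bears on it, cyclopropylmethyl to isopropyl, was flat, and cyclopropyl is another small carbon group of the same size on the same nitrogen. Among the compounds with values here, there is no measured example of a ring placed directly on this nitrogen, so the expectation rests on that single flat step. The expected outcome is a 1.1-fold higher number from compound 2 to compound 4 (0.06 log units; within the scatter), that is, no movement beyond the scatter. Compound 4 is therefore estimated at 80 nM, with a likely range from 40 nM to 170 nM.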

Compound 4, half-maximal effective concentration: 220 nM
For compound 4 the middle estimate is 2.8-fold (0.44 log units) below the measured one; measured number outside the range, above it.
By their numbers in this assay, from the lowest: compounds 2 and 1 (each within the scatter of the next); then compounds 3 and 4 (each within the scatter of the next).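

The amide-type nitrogen of the shared core proved more sensitive than the earlier flat step suggested: in this assay, cyclopropyl in place of isopropyl gives a 3.1-fold higher number from compound 2 to compound 4 (0.50 log units; beyond the scatter) even though both groups have the same count of three carbon atoms and differ in that cyclopropyl closes them into a three-membered ring. The three-membered ring alone does not go with the higher number, since compound 1 carries one too and stays within the scatter of compound 2, while removing the carbon that links this ring to the nitrogen gives a 2.8-fold higher number from compound 1 to compound 4 (0.44 log units; beyond the scatter) as a step of modest size. Nothing shown here explains why a ring placed directly on this nitrogen goes with the higher number.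

The compounds shown leave open how a cyclobutyl ring, a longer chain such as butyl or a chain ending in an amine would read on this nitrogen. Going by these compounds, each step also rests on a single pair of compounds on one core, so whether the same change gives a similar step on another core remains unknown.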